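Ortho-substituted aryl imidazole series: methoxy to chloro

This account rests on a few compounds, and the source may have more. Where it says the series, first, only, none or still open, it means among the compounds named here.

Compound 1 `Clc1ccccc1C1CCc2nc[nH]c2C1` and compound 2 `COc1ccccc1C1CCc2nc[nH]c2C1` share one core; compound 3 `COc1ccccc1C1Cc2nccn2C1` and compound 4 `Clc1ccccc1C1Cc2nccn2C1` share another, and the difference between the two cores is not broken down here. In a functional assay on CHO cells for agonist activity at Alpha-1B adrenergic receptor (Homo sapiens), read by FLIPR and calcium flux (on this read-out lower numbers stand for an effect already at smaller amounts and higher numbers for an effect only at larger amounts of compound), compound 1 gives only a limit, > 10000 nM. In this assay compound 2 likewise gives only a limit, > 10000 nM. For compound 3 this assay reports "not determined" (no result reported). The change chloro in place of methoxy on an aromatic carbon gives a step that the two limits leave unreadable from compound 2 to compound 1. The change chloro in place of methoxy on an aromatic carbon is the same kind of change, the place differing only in that it is ortho to a group of 8 heavy atoms rather than 9. Compound 4 is expected in this assay at about 20000 nM, between 5000 nM and 100000 nM, resting on (the limit of > 10000 nM in this assay, at which 2 of the 3 values shown sit); the uncertainty is wide.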

Compound 4, half-maximal effective concentration: 1100 nM
Compound 4: the middle estimate sits 18-fold (1.26 log units) above what was measured, and the stated range ends above it.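

In this assay compound 3 gives "not determined" (no result reported) and compound 4 gives 1100 nM, so no step can be read between them. On these data alone, whether chloro in place of methoxy changes the read-out on the core of compound 4 remains open.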